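A few compounds are considered here, and "the series" means these few. Any claim that something is new, unique, unknown or untested is made for them only; others in the source may bear on it.

Measured compounds:
compound 1 `COc1ccc(/C=C2\CCC/C(=C\c3ccccc3)C2=O)c(OC)c1`: 41%
compound 2 `COc1cccc(/C=C2\CCC/C(=C\c3ccccc3)C2=O)c1OC`: 31.8%
compound 3 `O=C1/C(=C/c2ccccc2)CCC/C1=C\c1ccc(Cl)c(Cl)c1`: 48.4%

In an assay on isolated protein for inhibition of Alpha glucosidase (Homo sapiens), with stated times of 5 min and 15 min, tested at 50 uM (a lower number here means less inhibition, a higher number more inhibition at the concentration tested (going by the name of the read-out)), compound 1 gives 41%, the second highest of the three numbers. Compound 3 gives 48.4% and compound 2 gives 31.8%, and both of these lie within the scatter of the number for compound 1, so the three measured compounds cannot be ranked against each other.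

Compound 4 `COc1ccc(/C=C2\CCC/C(=C\c3ccccc3)C2=O)cc1` is not yet measured. Against compound 1 the change is hydrogen in place of methoxy on an aromatic carbon. Within the data shown here, no pair of measured compounds isolates this change, and the measured numbers give no steps beyond the scatter, so the step from compound 1 to compound 4 is expected to stay within the scatter, with no clear direction, as a number 3 percentage points lower from compound 1 to compound 4 (within the scatter). Compound 4 is therefore estimated at 38%, in the range 22% to 54%.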

Compound 4, a percentage reported as inhibition, at one concentration (the size of the read-out at that concentration, not a potency): 31.4%
For compound 4 the middle estimate is 6.6 percentage points above the measured one; the range from low to high includes it.
By their numbers in this assay, from the lowest: compounds 4, 2, 1 and 3 (each within the scatter of the next, the first and the last beyond it).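

In this assay, among these compounds, hydrogen in place of methoxy on this aromatic carbon, ortho to a large group, gives a number 9.6 percentage points lower from compound 1 to compound 4 (within the scatter), the first step that isolates a single change. At this position, then, the methoxy group is not shown to be required for the inhibition read at this concentration, and this one step sets no direction. No measurement bears on a cause for the step.

Going by these compounds, whether an amine or a carboxylic acid on this carbon would move the number beyond the scatter stays open. So does the contribution of the methoxy group meta to this position, which compound 4 retains.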